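A few compounds are considered here, and "the series" means these few. Any claim that something is new, unique, unknown or untested is made for them only; others in the source may bear on it.

Of the compounds shown here, three sharing one core have been tested in a functional assay on K562 cells (Homo sapiens), read by MTT assay, with a stated time of 72 h; on this read-out lower numbers stand for stronger inhibition and higher numbers for weaker inhibition. Compound 1 `Nc1nc2c(c(-c3ccccc3)cn2[C@@H]2O[C@H](CO)[C@@H](O)[C@H]2O)c(=O)[nH]1` gives > 20000 nM, which is a limit of the assay rather than a number. Compound 2 `O=c1[nH]cnc2c1c(-c1ccsc1)cn2[C@@H]1O[C@H](CO)[C@@H](O)[C@H]1O` gives > 20000 nM, again a limit rather than a number. Among the compounds with values here, compound 3 `O=c1[nH]cnc2c1c(-c1ccoc1)cn2[C@@H]1O[C@H](CO)[C@@H](O)[C@H]1O` gives 14500 nM, the only actual number among the three. Two of the three values sit at the limit of > 20000 nM in this assay, at which 2 of the 3 values shown sit. Within the data shown here, the single step between measured compounds that differ in one place, an at least 1.3-fold lower number from compound 2 to compound 3 (0.13 log units; that floor lies within the scatter), starts from a limit, so only a floor for its size is known. Compound 4 `Nc1nc2c(c(-c3ccoc3)cn2[C@@H]2O[C@H](CO)[C@@H](O)[C@H]2O)c(=O)[nH]1` has not yet been measured. It differs from compound 3 by amino in place of hydrogen on an aromatic carbon. Among the measured compounds shown here, no measured step adds an amino group in this way, so no step bears directly on the change. Compound 1, which carries that amino group on the same core with a different aromatic group, sits at the limit. The expected step is a 1.2-fold higher number from compound 3 to compound 4 (0.09 log units; within the scatter), with a real chance that only a limit is reported. Compound 4 is estimated at 18000 nM, with a range from 8000 nM to 40000 nM.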

Compound 4, half-maximal inhibitory concentration: 12500 nM
The estimate for compound 4 lay 1.4-fold (0.16 log units) above the measured number; measured number inside the range.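

In this assay, amino in place of hydrogen, on the aromatic carbon between two ring nitrogen atoms, gives a 1.2-fold lower number from compound 3 to compound 4 (0.06 log units; within the scatter) with furan-3-yl held fixed, so with this group in place the two compounds cannot be told apart. With the amino group kept, furan-3-yl in place of phenyl gives an at least 1.6-fold lower number from compound 1 to compound 4 (0.20 log units; that floor lies within the scatter) and so shows no change beyond the scatter, though its true size may be larger. Only a floor is known for that step, as compound 1 is held at a limit and not a number: the limit of > 20000 nM in this assay, at which 2 of the 4 values shown sit.

As far as these compounds go, whether a methylamino group, a dimethylamino group or a hydroxyl group at this same carbon would move the number beyond the scatter remains open. Also open, from the compounds shown here alone, is how the amino group acts when thiophen-3-yl replaces furan-3-yl on the shared core.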